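This account rests on a few compounds, and the source may have more. Where it says the series, first, only, none or still open, it means among the compounds named here.

In a physicochemical assay for solubility (a lower number here means a less soluble compound, a higher number a more soluble compound), compound 3 `CNC(=O)c1cc(C(=O)NC2CC2)cn(Cc2ccccc2F)c1=O` gives >= 145 ug/mL, which is a limit of the assay and not a number. Compound 1 `CNC(=O)c1cc(C(=O)NC2CC2)cn(Cc2ccc(F)cc2)c1=O` gives >= 162 ug/mL, also a limit. Compound 2 `CNC(=O)c1cc(C(=O)NC2CC2)cn(CC2CCCOC2)c1=O` gives >= 131 ug/mL, likewise a limit. Compound 3 therefore has no exact value to stand on, and neither do the two compounds it can be compared with.

Compound 4 `CNC(=O)c1cc(C(=O)NC2CC2)cn(CC2CCOCC2)c1=O` keeps the shared core and changes one group: oxan-4-yl in place of 2-fluorophenyl on a saturated chain carbon bound to an aromatic nitrogen. In words, oxan-4-yl replaces 2-fluorophenyl on a saturated chain carbon bound to an aromatic nitrogen. Compound 2 carries the related oxan-3-yl, so a step that the two limits leave unreadable from compound 2 to compound 3 bears most directly on this change. a step that the two limits leave unreadable from compound 1 to compound 2 and a step that the two limits leave unreadable from compound 1 to compound 3 bear on it too. None of the three has a readable size, so they offer no sign of a real shift in either direction. No step beyond the scatter is expected, and the expected size is a number no higher from compound 3 to compound 4 (the limit leaves the size open). For compound 4 the estimated value is 145 ug/mL, within an expected range of 100 ug/mL to 190 ug/mL.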

Compound 4, solubility: >= 165 ug/mL
Compound 4: no number, only a limit (the forecaster's own chance of this, stated with the estimate: 85%); middle value at least 1.1-fold (0.05 log units) away from the limit.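

In this assay, compound 4 gives only a limit, as do compound 1, compound 2 and compound 3, so no step among these four compounds can be read. The compounds shown leave open whether oxan-4-yl, oxan-3-yl, 2-fluorophenyl and 4-fluorophenyl differ in solubility at all.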